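The source may report more compounds than this note shows. Statements on the series, on what has been measured and on what is new or still open speak of the compounds shown alone.

Measured compounds in a functional assay on RKE cells for antagonist activity at Vasoactive intestinal polypeptide receptor 1 (Rattus norvegicus), read by HTRF and cAMP accumulation, with stated times of 10 min and 30 min; a lower number here means a stronger inhibitor, a higher number a weaker inhibitor:
Compound 1 `CCC(=O)Nc1sc2c(c1C#N)CCCC2`: 12000 nM
Compound 2 `CC(C)c1cc(C(C)(C)C)cc(-c2cccc(C#N)c2)c1CO`: > 50000 nM

Among the compounds with values here, of the two figures in this assay, only the one for compound 1 is a number. For compound 2 the value > 50000 nM is a limit of this assay and not a measured number, so compound 2 can only be placed at that limit (the limit of > 50000 nM in this assay, at which 1 of the 2 values shown sits). This leaves the position of compound 2 open on the weak side, and its distance to compound 1 cannot be stated.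

Compound 3 `CC(C)c1cc(C(C)(C)C)cc(-c2cccc(Cl)c2)c1CO` differs from compound 2 in one place: chloro in place of cyano on an aromatic carbon. Within the data shown here, no measured pair in this set shows such an exchange, so there is no direct guide to its size. Compound 3 is expected to stay near the limit of this assay, with the step from compound 2 to compound 3 estimated at a step that the limit leaves unreadable from compound 2 to compound 3, within the scatter. For compound 3 the estimate is 60000 nM, between 20000 nM and 200000 nM.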

Compound 3, half-maximal inhibitory concentration: 100 nM
The estimate for compound 3 lay 600-fold (2.78 log units) above the measured number, and the stated range ends above it.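

In this assay, chloro in place of cyano on an aromatic carbon, meta to a large group, gives an at least 500-fold lower number from compound 2 to compound 3 (2.69 log units; beyond the scatter). This pair shows what compound 1 and compound 2 alone could not: the core of compound 2 can give a measurable inhibitor, and a single exchange at this place on the six-membered aromatic ring decides whether it does. Compound 2 stands at a limit and not a measured number, so the true size of this step stays unknown on its weak side: the limit of > 50000 nM in this assay, at which 1 of the 3 values shown sits.

The exchange removes a triple bond and a hydrogen-bond acceptor and changes the heavy atoms all at once, and the pair cannot tell which of these matters. From the compounds shown here alone, how fluoro, methyl or methoxy would behave at this place also remains open.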